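Trifluoromethyl Added to One Phenyl of Compound 2

A few compounds are considered here, and "the series" means these few. Any claim that something is new, unique, unknown or untested is made for them only; others in the source may bear on it.

Measured so far in an assay for binding affinity to leukotriene B4 receptor 1 (Homo sapiens); a lower number here means a stronger inhibitor, a higher number a weaker inhibitor:
Compound 1, `COC(=O)CCCCCOc1cc(-c2ccccc2)cc(-c2ccccc2)n1`: 100 nM
Compound 2, `O=C(O)CCCCCOc1cc(-c2ccccc2)cc(-c2ccccc2)n1`: 30 nM
Compound 3, `CC(C)(CCCCCCOc1cc(-c2ccccc2)cc(-c2ccccc2)n1)C(=O)O`: 60 nM

Compound 2 has the lowest of the three numbers. The nearest is compound 3, and the step of a 2.0-fold higher number from compound 2 to compound 3 (0.30 log units; within the scatter) lies within the scatter, so the two cannot be ordered. Among the measured compounds shown here, the only step beyond the scatter is a 3.3-fold lower number from compound 1 to compound 2 (0.52 log units; beyond the scatter), a modest one. Compound 4, `O=C(O)CCCCCOc1cc(-c2ccc(C(F)(F)F)cc2)cc(-c2ccccc2)n1`, differs from compound 2 by one change: trifluoromethyl in place of hydrogen on an aromatic carbon. For the measured compounds named here, none of the measured steps touches the aryl rings; all three vary the chain and its acid or ester end, so no measured step bears directly on this change. With nothing in the shown data speaking for a shift in either direction, the expected step of no change at the digits printed from compound 2 to compound 4 (within the scatter) is none beyond the scatter, and compound 4 is estimated at 30 nM with a range from 10 nM to 100 nM in this assay.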

Compound 4, half-maximal inhibitory concentration: 150 nM
The estimate for compound 4 lay 5.0-fold (0.70 log units) below the measured number, and the stated range ends below it.
By their numbers in this assay, from the lowest: compounds 2, 3, 1 and 4 (each within the scatter of the next, the first and the last beyond it).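

In this assay, a 5.0-fold higher number from compound 2 to compound 4 (0.70 log units; beyond the scatter) is the first step shown at an aromatic carbon, and it lies beyond the scatter. The earlier steps shown here varied only the chain and its acid or ester end, whereas this one shows that the number also responds to a change on the aryl part: going from phenyl to 4-(trifluoromethyl)phenyl, with the acid chain of compound 2 kept, raises the number rather than leaving it unchanged. Nothing in the data shown gives a reason for this rise.

From the compounds shown here alone, it remains open whether a fluorine, a methyl or a methoxy group on this same carbon would raise the number as well, or whether trifluoromethyl on the other phenyl would do so. Also open, going by these compounds, is whether the same rise would appear on the chain of compound 3.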